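Swapping Methoxy for Oxan-4-yl on a Shared Core

The compounds below may be only part of what the source reports. "The series", "measured", "known", "first", "only" and "open" are said of these compounds alone.

Compound 1 `COc1cc2c(cn1)Oc1ccc(NC(=O)c3ccc(Cl)cn3)cc1[C@@]21COC(N)=N1` was tested in an ADME assay on microsomes from liver (Rattus norvegicus) for metabolic stability, read by LC-MS, using NADPH, with a stated time of 30 min, tested at 1 uM; a lower number here means slower removal, a higher number faster removal of the compound. In this assay compound 1 gives < 14 mL.min-1.g-1, and this is a limit of the assay rather than a measured number (the limit of < 14 mL.min-1.g-1 in this assay, at which 1 of the 3 values shown sits). Two further compounds share the same core but carry other groups. Compound 2 `CC#Cc1cncc(-c2ccc3c(c2)[C@@]2(COC(N)=N2)c2cc(C4=CCCOC4)ncc2O3)c1` gives 45 mL.min-1.g-1 in this assay, and compound 3 `NC1=N[C@@]2(CO1)c1cc(-c3cncc(C#CC4CC4)c3)ccc1Oc1cnc(C3=CCOCC3)cc12` gives 23 mL.min-1.g-1. Among the three values, only a limit is known for compound 1, and it sits at the lowest point of the numbers shown, with compound 2 and compound 3 reading above it.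

Compound 4 `NC1=N[C@@]2(CO1)c1cc(NC(=O)c3ccc(Cl)cn3)ccc1Oc1cnc(C3CCOCC3)cc12` has not yet been measured. It differs from compound 1 in one place: oxan-4-yl in place of methoxy on an aromatic carbon. For the measured compounds named here, no measured pair of compounds differs only at this spot, so the size of the step cannot be read directly from the data. Compound 2 and compound 3, which carry ring groups in place of the methoxy of compound 1, both return numbers above the limit of compound 1. On that basis a modest step from compound 1 to compound 4 towards faster removal is expected, an at least 1.4-fold higher number from compound 1 to compound 4 (0.15 log units; that floor lies within the scatter), though a step within the scatter would not surprise. Compound 4 is estimated at 20 mL.min-1.g-1, with a range from 9 mL.min-1.g-1 to 40 mL.min-1.g-1.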

Compound 4, intrinsic clearance in microsomes: 79 mL.min-1.g-1
For compound 4 the middle estimate is 4.0-fold (0.60 log units) below the measured one, and the stated range ends below it.
By their numbers in this assay, from the lowest: compounds 3, 2 and 4 (each within the scatter of the next, the first and the last beyond it). At a limit, below all of these: compound 1.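

In this assay, the change from methoxy to oxan-4-yl on this aromatic carbon, next to the ring nitrogen, now has a size that can be read directly: the shared core gives an at least 5.6-fold higher number from compound 1 to compound 4 (0.75 log units; beyond the scatter), which is beyond the usual scatter. The reading for compound 1 is a limit and not a number, so this step is only a floor and the real change may be larger: the limit of < 14 mL.min-1.g-1 in this assay, at which 1 of the 4 values shown sits. Both groups count one hydrogen-bond acceptor and no donor, so the difference in those counts is nil and what enters is a six-membered non-aromatic ring with more carbon, yet a single pair cannot say which feature of that ring matters.

The compounds shown leave open whether a cyclohexyl group, with carbon in place of the ring oxygen, or a small group such as an ethoxy or an amine, would read nearer compound 1 or compound 4 in this assay. For the compounds shown here, compound 2 and compound 3 differ from compound 4 in more than one place and give no second step at this position.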